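Bringing Back an Aromatic Ring on the Amine Side Chain

The compounds below may be only part of what the source reports. "The series", "measured", "known", "first", "only" and "open" are said of these compounds alone.

Compound 3 `CCC(CC)CN1CCC(C(=O)Nc2cc(Cl)c(N)cc2OC)CC1` carries a pentan-3-yl group on a saturated chain carbon bound to an amine nitrogen in a ring. In a functional assay on the whole organism for antagonist activity, with Mus musculus as the target (a lower number here means that less compound is needed, a higher number that more compound is needed for the effect), compound 3 gives > 10 mg/kg, which is a limit of the assay and not a number. Compound 1 `CCOc1ccc(CN2CCC(C(=O)Nc3cc(Cl)c(N)cc3OC)CC2)cc1`, with 4-ethoxyphenyl at that place, gives 6.3 mg/kg in this assay. Compound 2 `COc1cc(N)c(Cl)cc1NC(=O)C1CCN(CC2CCCCCC2)CC1`, with cycloheptyl there, gives > 10 mg/kg, again only a limit. Limits therefore dominate the picture: the limit of > 10 mg/kg in this assay, at which 2 of the 3 values shown sit. The step of an at least 1.5-fold higher number from compound 1 to compound 3 (0.20 log units; that floor lies within the scatter) and the step of an at least 1.5-fold higher number from compound 1 to compound 2 (0.20 log units; that floor lies within the scatter) both show a higher number when the aromatic group gives way to a saturated one, though each floor lies within the scatter, and the step that the two limits leave unreadable from compound 2 to compound 3 cannot be read. Compound 4 `COc1cc(N)c(Cl)cc1NC(=O)C1CCN(Cc2ccc(F)cc2)CC1` makes the opposite kind of change: 4-fluorophenyl in place of pentan-3-yl on a saturated chain carbon bound to an amine nitrogen in a ring. Because compound 1 with its aromatic group gives 6.3 mg/kg, an aromatic ring is expected to bring compound 4 back down, a step of an at least 1.6-fold lower number from compound 3 to compound 4 (0.22 log units; that floor lies within the scatter). The estimate for compound 4 is 6 mg/kg, with a range from 2.5 mg/kg to 15 mg/kg.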

Compound 4, dose for half-maximal effect: 0.6 mg/kg
For compound 4 the middle estimate is 10-fold (1.00 log units) above the measured one, outside the stated range (below it).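

Swapping a saturated group for an aromatic one at this place now gives a step well beyond the scatter: an at least 16-fold lower number from compound 3 to compound 4 (1.22 log units; beyond the scatter), and with cycloheptyl leaving, an at least 16-fold lower number from compound 2 to compound 4 (1.22 log units; beyond the scatter). The aromatic ring alone does not settle the outcome, as the change of fluoro in place of ethoxy on an aromatic carbon gives an 11-fold lower number from compound 1 to compound 4 (1.02 log units; beyond the scatter), so what the ring carries also counts in this assay. The steps from compound 2 and compound 3 start from limits of the assay and not from numbers, so their full size stays unknown because of the values that sit at the limit: the limit of > 10 mg/kg in this assay, at which 2 of the 4 values shown sit.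

The compounds shown leave open how a plain phenyl ring, with neither fluoro nor ethoxy, would compare at this place. They also leave open whether chloro or methoxy on the ring would behave as fluoro does or as ethoxy does.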